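The source may report more compounds than this note shows. Statements on the series, on what has been measured and on what is new or still open speak of the compounds shown alone.

Measured so far:
- compound 1 `O=C1C(NC2CCCC2)=CC(=O)c2c1nc1n2[C@H]2OC[C@@H](O)[C@H]2OC1`: > 16000 nM
- compound 2 `O=C1C=C(Nc2ccc(C(F)(F)F)cc2)C(=O)c2c1nc1n2[C@H]2OC[C@@H](O)[C@H]2OC1`: 5500 nM
- compound 3 `O=C1C=C(NC2CCCC2)C(=O)c2c1nc1n2[C@H]2OC[C@@H](O)[C@H]2OC1`: > 16000 nM

All three were tested in a functional assay on ECa-109 cells for inhibition, with ECa-109 cell line (Homo sapiens) as the target, read by sulforhodamine B assay; on this read-out lower numbers stand for stronger inhibition and higher numbers for weaker inhibition. Compound 1 gives > 16000 nM, which is a limit of the assay and not a number. Compound 3 likewise gives > 16000 nM, again a limit. Within the data shown here, compound 2 gives 5500 nM, the only finished number among the three. Compound 1 therefore stands at the limit of > 16000 nM in this assay, at which 2 of the 3 values shown sit, and nothing finer is known about it.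

Compound 4 `CCc1ccc(NC2=CC(=O)c3c(nc4n3[C@H]3OC[C@@H](O)[C@H]3OC4)C2=O)cc1` is compound 1 with 4-ethylphenyl in place of cyclopentyl on an amine nitrogen. Among the measured compounds shown here, the one measured step that bears on this change is an at least 2.9-fold higher number from compound 2 to compound 3 (0.46 log units; beyond the scatter), which runs in the opposite direction: there the aryl group on the amine nitrogen went with the stronger inhibition and the cyclopentyl with the weaker. Read backwards, putting an aromatic ring in place of cyclopentyl is expected to lower the number, so the step from compound 1 to compound 4 should go towards stronger inhibition. Its size is uncertain because compound 1 sits at the limit of > 16000 nM in this assay, at which 2 of the 3 values shown sit, and because this rests on a single pair measured on a differently substituted core. Compound 4 is therefore expected to give about 6000 nM, somewhere between 2000 nM and 20000 nM. That amounts to an expected at least 2.6-fold lower number from compound 1 to compound 4 (0.42 log units; beyond the scatter).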

Compound 4, half-maximal inhibitory concentration: > 4000 nM
Compound 4: a limit, no number (the forecaster's own chance of this, stated with the estimate: 25%); the middle value is on the limit's open side.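

Compound 1 and compound 4 both end at limits of the assay rather than at finished numbers, so no step can be read between them. The compounds shown leave open whether 4-ethylphenyl in place of cyclopentyl on an amine nitrogen changes inhibition on this core at all, and if so, in which direction and by how much.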